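One Trifluoromethyl, Added Twice on Two Different Cores

The source may report more compounds than this note shows. Statements on the series, on what has been measured and on what is new or still open speak of the compounds shown alone.

Compound 1 `Cc1nc(N(C)C(=O)NC(=O)c2c(F)cccc2F)sc1C(=O)N/N=C/c1cccc(C(F)(F)F)c1` and compound 3 `Cc1nc(N(C)C(=O)NC(=O)c2c(F)cccc2F)sc1C(=O)N/N=C/c1cc(C(F)(F)F)cc(C(F)(F)F)c1` share one core and differ in a single place: trifluoromethyl in place of hydrogen on an aromatic carbon. In a functional assay on MCF7 cells (Homo sapiens) for inhibition, read by MTT assay, with a stated time of 72 h (on this read-out higher numbers stand for weaker inhibition and lower numbers for stronger inhibition), compound 1 gives 28.2 ug/mL, and in the same assay compound 3 gives 11.6 ug/mL. That single change therefore produced a 2.4-fold lower number from compound 1 to compound 3 (0.39 log units; beyond the scatter).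

Compound 2 `CNc1nc(C(F)(F)F)c(C(=O)N/N=C/c2cccc(C(F)(F)F)c2)s1` is built on another core, and how its core differs from the core of compound 1 is not broken down here. In this assay compound 2 gives only a limit, > 100 ug/mL, which is the limit of > 100 ug/mL in this assay, at which 1 of the 3 values shown sits, and not a number.

Compound 4 `CNc1nc(C(F)(F)F)c(C(=O)N/N=C/c2cc(C(F)(F)F)cc(C(F)(F)F)c2)s1` is the compound still to be measured. It differs from compound 2 by trifluoromethyl in place of hydrogen on an aromatic carbon. The description of the place is the same word for word as for the pair of compound 1 and compound 3, so this is the same change, occurring for the second time among these four compounds.

The step from compound 2 to compound 4 is expected to be a number no higher from compound 2 to compound 4 (the limit leaves the size open), and this expectation rests on the measured pair because the step of a 2.4-fold lower number from compound 1 to compound 3 (0.39 log units; beyond the scatter) was the same change made on the first core. Because compound 2 gave only > 100 ug/mL, the starting point itself is uncertain, and compound 4 may well also return a limit. In this assay compound 4 is expected to give roughly 100 ug/mL, lying somewhere between 40 ug/mL and 300 ug/mL.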

Compound 4, half-maximal inhibitory concentration: > 100 ug/mL
Compound 4: only a limit was reported; the forecaster's own chance of this, stated with the estimate: 55%; the middle value sits exactly at the limit.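

Compound 2 and compound 4 both give only a limit in this assay, not a number, so the step between them cannot be read: the limit of > 100 ug/mL in this assay, at which 2 of the 4 values shown sit.

The compounds shown leave open whether the trifluoromethyl change behind a 2.4-fold lower number from compound 1 to compound 3 (0.39 log units; beyond the scatter) does anything at all on the core shared by compound 2 and compound 4.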